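Compound 3 to compound 4: ethoxy to 2,2,2-trifluoroethoxy

A few compounds are considered here, and "the series" means these few. Any claim that something is new, unique, unknown or untested is made for them only; others in the source may bear on it.

Three amides sharing one core have been measured in an ADME assay on LLC-PK1 cells (Sus scrofa) for permeability; on this read-out lower numbers stand for lower permeability and higher numbers for higher permeability: compound 1 (`C#CCOc1ccc(C(=O)Nc2cc(F)c(F)c([C@@]3(C)N=C(N)S[C@@]4(COC)C[C@H]43)c2)nc1`) gives 14 10^-6 cm/s, compound 2 (`C#CCOc1cnc(C(=O)Nc2cc(F)c(F)c([C@@]3(C)N=C(N)S[C@@]4(COC)C[C@H]43)c2)c(C)c1`) gives 19 10^-6 cm/s, and compound 3 (`CCOc1cnc(C(=O)Nc2cc(F)c(F)c([C@@]3(C)N=C(N)S[C@@]4(COC)C[C@H]43)c2)cn1`) gives 25 10^-6 cm/s. Compound 3 stands within the scatter of both other compounds, so the three values form a single group.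

Compound 4 (`COC[C@]12C[C@H]1[C@@](C)(c1cc(NC(=O)c3cnc(OCC(F)(F)F)cn3)cc(F)c1F)N=C(N)S2`) differs from compound 3 by trifluoromethyl in place of methyl on a saturated chain carbon bound to an oxygen on an aromatic ring. This is trifluoromethyl in place of methyl on a saturated chain carbon bound to an oxygen on an aromatic ring. Within the data shown here, no measured step covers this change. The closest evidence is the three steps that alter the aromatic group on the carbonyl carbon: a 1.4-fold higher number from compound 1 to compound 2 (0.13 log units; within the scatter), a 1.8-fold higher number from compound 1 to compound 3 (0.25 log units; within the scatter) and a 1.3-fold higher number from compound 2 to compound 3 (0.12 log units; within the scatter). All three lie within the scatter, so on this thin evidence no step beyond the scatter is expected in this assay.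

The expected step is a 1.1-fold lower number from compound 3 to compound 4 (0.04 log units; within the scatter). For compound 4 the estimated value is 23 10^-6 cm/s, with an expected range from 12 10^-6 cm/s to 40 10^-6 cm/s.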

Compound 4, apparent permeability: 25 10^-6 cm/s
For compound 4 the middle estimate is 1.1-fold (0.04 log units) below the measured one; the range from low to high includes it.
By their numbers in this assay, from the lowest: compounds 1, 2, 3 and 4 (each within the scatter of the next).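

In this assay, among these compounds, trifluoromethyl in place of methyl on a saturated chain carbon bound to an oxygen on an aromatic ring gives no change at the digits printed from compound 3 to compound 4 (within the scatter), the one step confined to this chain. The earlier steps shown here either added a methyl on an aromatic carbon or replaced the whole aromatic group on the carbonyl carbon, so they could not isolate this position. Here, going from one heavy atom to four at the chain end, with three fluorine atoms entering, leaves the read-out unchanged at the digits printed. Nothing available explains this outcome.

Open, going by these compounds, is how the read-out responds to a longer chain such as propoxy, or to an amine in place of the ethoxy group. Also open, on these data alone, is whether the same exchange behaves alike with the aromatic groups of compound 1 and compound 2.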